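Working notes: step from compound 3 to compound 4

This account rests on a few compounds, and the source may have more. Where it says the series, first, only, none or still open, it means among the compounds named here.

Measured so far:
compound 1 `Cc1cccc(C(=O)NCN2CCC(c3nccs3)CC2)c1` gives 71%
compound 2 `COc1ccccc1C1CCN(CC(=O)Nc2cccc(C)c2)CC1` gives 43%
compound 3 `Cc1cc(NC(=O)CN2CCC(c3cccc[n+]3[O-])CC2)ccc1F` gives 75%

All three values come from a functional assay on HEK293 cells for agonist activity at D(4) dopamine receptor (Homo sapiens), read by FLIPR; a lower number here means a smaller maximal response, a higher number a larger maximal response. Compound 3 holds the highest of the three numbers, but compound 1 sits close to it, within the usual scatter, while compound 2 lies well below, beyond the scatter. Within the data shown here, no two measured compounds differ in only one place, so no single-change step is known from the data.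

Compound 4 `O=C(CN1CCC(c2cccc[n+]2[O-])CC1)Nc1cccc(Cl)c1Cl` has not been measured. It differs from compound 3 by 2,3-dichlorophenyl in place of 4-fluoro-3-methylphenyl on an amide-type nitrogen. Among the measured compounds shown here, with no comparable step measured, a change of small size is expected, staying within the scatter or dipping slightly below it. Compound 4 is expected to give 65% in this assay, in a range from 45% to 85%. The step of a number 10 percentage points lower from compound 3 to compound 4 (within the scatter) is thus expected to stay within the scatter.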

Compound 4, largest response reached (reported as efficacy), in percent of the reference or control that the assay uses: 66%
Estimate against measurement, compound 4: 1 percentage points below; the range from low to high includes it.
By their numbers in this assay, from the lowest: compound 2; then compounds 4, 1 and 3 (each within the scatter of the next).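

In this assay, among these compounds, 2,3-dichlorophenyl in place of 4-fluoro-3-methylphenyl on the amide-type nitrogen gives a number 9 percentage points lower from compound 3 to compound 4 (within the scatter) and provides the first single-place comparison. This position therefore tolerates this exchange of aromatic substituents without a change beyond the scatter. No measured property bears on this step, so the result remains without an explanation. Still open, going by these compounds, is whether the response would hold with a saturated group such as cyclohexyl on this nitrogen. A phenyl ring carrying an amine or a carboxylic acid at this position also remains untested in the compounds shown.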